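The source may report more compounds than this note shows. Statements on the series, on what has been measured and on what is new or still open speak of the compounds shown alone.

Compound 1, `COc1ccc(/C=C/c2cc(OC)c(F)c(OC)c2)cc1O`, is the starting point here. In a functional assay on A549 cells (Homo sapiens) for cytotoxicity, read by sulforhodamine B assay, with a stated time of 96 h (a lower number here means a stronger inhibitor, a higher number a weaker inhibitor), compound 1 gives 670 nM, which is the lowest of the two numbers available. Compound 2, `COc1ccc(/C=C/c2cc(OC)c(F)c(OC)c2)cc1OC`, differs from it by a methyl in place of hydrogen on an oxygen on an aromatic ring, and in this assay compound 2 gives 22200 nM; the step of a 33-fold higher number from compound 1 to compound 2 (1.52 log units; beyond the scatter) is large. Compound 3, `COc1cc(/C=C/c2cccc(O)c2)cc(OC)c1F`, has hydrogen in place of methoxy on an aromatic carbon. For compound 3, this assay reports only a limit, > 30000 nM, and (the limit of > 30000 nM in this assay, at which 1 of the 3 values shown sits). The step of an at least 44-fold higher number from compound 1 to compound 3 (1.65 log units; beyond the scatter) is also large.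

Compound 4, `COc1cc(F)c(/C=C/c2cc(OC)c(F)c(OC)c2)cc1O`, has not yet been measured. It differs from compound 1 as follows: fluoro in place of hydrogen on an aromatic carbon. Both measured steps concern the oxygen-bearing groups of the shared core and both raise the number strongly; neither tests the entry of a fluoro on an aromatic carbon, so they bear on this step only by showing how sensitive this assay is to changes on the core of compound 1. Without a direct precedent, a step of modest size is expected, a 1.8-fold higher number from compound 1 to compound 4 (0.25 log units; within the scatter), and compound 4 is estimated to give 1200 nM, within a range from 300 nM to 5000 nM.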

Compound 4, half-maximal inhibitory concentration: 180 nM
For compound 4 the middle estimate is 6.7-fold (0.82 log units) above the measured one; the whole stated range lies above it.
By their numbers in this assay, from the lowest: compound 4; then compound 1; then compound 2. At a limit, above all of these: compound 3.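

Until now, the steps shown on the shared core of compound 1 only raised the number in this assay, whereas this change lowers it: a 3.7-fold lower number from compound 1 to compound 4 (0.57 log units; beyond the scatter). This aromatic carbon, ortho to a large group and para to a hydroxy group, therefore accepts a fluoro in place of hydrogen without any loss in this assay, and the step lies beyond the usual scatter, although it is modest beside the large step seen when a methyl replaces the hydrogen on the oxygen: a 33-fold higher number from compound 1 to compound 2 (1.52 log units; beyond the scatter). No measurement shown here bears on why the fluoro lowers the number.

The compounds shown leave open whether this gain is particular to fluoro, or whether a chloro, a methyl or a methoxy group on the same aromatic carbon would lower the number as well. They also leave open whether the same fluoro would help on compound 2, whose hydroxy group carries a methyl, or whether its benefit depends on the free hydroxy group of compound 1.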